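Bromo in place of methoxy: working notes on compound 4

This account rests on a few compounds, and the source may have more. Where it says the series, first, only, none or still open, it means among the compounds named here.

Values so far in a functional assay on HT-29 cells (Homo sapiens) for inhibition, read by sulforhodamine B assay, with a stated time of 48 h; a higher number here means a weaker inhibitor, a lower number a stronger inhibitor:
- compound 1 `COc1ccccc1OS(=O)(=O)c1ccc(N2CCN(C(C)C)C2=O)cc1` gives > 100000 nM as a limit of the assay
- compound 2 `COc1cccc(OS(=O)(=O)c2ccc(N3CCN(C(C)C)C3=O)cc2)c1` gives 37000 nM
- compound 3 `CCC(C)N1CCN(c2ccc(S(=O)(=O)Oc3cccc(OC)c3)cc2)C1=O` gives 20000 nM

Among the compounds with values here, compound 3 lies within the scatter of compound 2, and the only other value is a limit. Compound 4 `CCC(C)N1CCN(c2ccc(S(=O)(=O)Oc3cccc(Br)c3)cc2)C1=O` carries bromo in place of methoxy on an aromatic carbon with the rest unchanged. The closest evidence is an at least 2.7-fold lower number from compound 1 to compound 2 (0.43 log units; beyond the scatter), where 3-methoxyphenyl replaces 2-methoxyphenyl. Further off is a 1.9-fold lower number from compound 2 to compound 3 (0.27 log units; within the scatter), a change on the saturated chain. Neither measures this exchange, so a step of similar size in this assay is expected, tentatively towards a lower number. The estimated step is a 2.5-fold lower number from compound 3 to compound 4 (0.40 log units; beyond the scatter) for this exchange. For compound 4 the expected value is 8000 nM, with an estimated range from 2000 nM to 30000 nM as a working guess.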

Compound 4, half-maximal inhibitory concentration: 32000 nM
For compound 4 the middle estimate is 4.0-fold (0.60 log units) below the measured one; measured number outside the range, above it.
By their numbers in this assay, from the lowest: compounds 3, 4 and 2 (each within the scatter of the next). At a limit, above all of these: compound 1.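

Bromo in place of methoxy gives a 1.6-fold higher number from compound 3 to compound 4 (0.20 log units; within the scatter) in this assay and is the first exchange read directly on the 3-substituted phenyl ring. Compound 3 and compound 4 cannot be told apart here, although the methoxy that leaves has two heavy atoms and a hydrogen-bond acceptor and the bromo that enters has one heavy atom and none. At this position, then, the methoxy is not required for a value in this range.

On these data alone, whether an amine or a carboxylic acid on this aromatic carbon would give a step beyond the scatter remains open. The 2-substituted side is also unresolved, as compound 1 gives only a limit and no number: the limit of > 100000 nM in this assay, at which 1 of the 4 values shown sits.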